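The source may report more compounds than this note shows. Statements on the series, on what has been measured and on what is new or still open speak of the compounds shown alone.

Values in a functional assay on HCT-116 cells (Homo sapiens) for inhibition, read by sulforhodamine B assay, with a stated time of 48 h; a lower number here means a stronger inhibitor of growth, a higher number a weaker inhibitor of growth:
- compound 1 `Cc1ccc(NC(=O)/C=C/c2ccccc2)c(C(N)=O)c1`: 3200 nM
- compound 2 `NC(=O)c1cc(Br)ccc1NC(=O)/C=C/c1ccccc1`: 663 nM
- compound 3 `NC(=O)c1cc(I)ccc1NC(=O)/C=C/c1ccccc1`: 430 nM

In this assay, compound 3 at 430 nM is level with compound 2 within the scatter, as a 1.5-fold lower number from compound 2 to compound 3 (0.19 log units; within the scatter) shows. Both lie clearly on the more growth-inhibiting side of compound 1, with a 7.4-fold lower number from compound 1 to compound 3 (0.87 log units; beyond the scatter) and a 4.8-fold lower number from compound 1 to compound 2 (0.68 log units; beyond the scatter).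

The next compound is compound 4 `NC(=O)c1cc(I)ccc1NC(=O)/C=C/c1ccccc1Cl`, with the change chloro in place of hydrogen on an aromatic carbon, going from phenyl to 2-chlorophenyl.

None of the three measured steps bears directly on this change. All of them exchange methyl, bromo or iodo at one other aromatic carbon, and none alters the phenyl that takes the new chloro. For the measured compounds named here, they show only that a single-atom exchange has ranged from a step within the scatter to a modest one. Going by the values given here, the data hold no example of substitution on this phenyl, so the direction is poorly defined. No step beyond the scatter is expected, with a slight lean towards a lower number. The estimated change is a 1.2-fold lower number from compound 3 to compound 4 (0.09 log units; within the scatter).

For compound 4 the expected value is 350 nM, with an estimated range of 110 nM to 1100 nM.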

Compound 4, concentration for 50% growth inhibition: 509 nM
Compound 4: the middle estimate sits 1.5-fold (0.16 log units) below what was measured; measured number inside the range.
By their numbers in this assay, from the lowest: compounds 3, 4 and 2 (each within the scatter of the next); then compound 1.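

In this assay, for the compounds shown here, the first change to the phenyl, phenyl to 2-chlorophenyl, gives (a 1.2-fold higher number from compound 3 to compound 4 (0.07 log units; within the scatter)), so a chloro on this aromatic carbon, ortho to a large group, produces no step beyond the scatter. The earlier steps shown here exchanged only methyl, bromo or iodo at another aromatic carbon and gave no reading on this phenyl; this first reading puts the replacement of hydrogen by a single chlorine atom within the scatter, leaving compound 4 level with compound 3. Nothing shown gives a measured reason for this result.

From the compounds shown here alone, the reading covers one position on the phenyl, one substituent and one partner at the other aromatic carbon, so it remains open whether 2-chlorophenyl would give a similar step with bromo as in compound 2 or with methyl as in compound 1. Also open, going by these compounds, is how this position would respond to a larger or differently functional group such as methoxy, an amine or a carboxylic acid, and how chloro would read at the other carbons of the phenyl.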